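The compounds below may be only part of what the source reports. "The series", "measured", "known", "first", "only" and "open" are said of these compounds alone.

Series in a functional assay on HO8910 cells (Homo sapiens) for inhibition, read by MTT assay, with a stated time of 24 h, tested at 0.1 ug/mL; on this read-out lower numbers stand for less inhibition of growth and higher numbers for more inhibition of growth at the one concentration tested:
- compound 1 `O=C(CCCCC1CCSS1)Nc1cccc(C(F)(F)F)c1` gives 5%
- compound 2 `O=C(CCCCC1CCSS1)Nc1ccc([N+](=O)[O-])c(C(F)(F)F)c1` gives "not active" (no number reported)
- compound 3 `O=C(CCCCC1CCSS1)Nc1ccccn1` gives 1.14%

Compound 2 has no number, so it cannot be placed on a scale against the other two. It is reported only as "not active" (no number reported). The two numbers that exist, for compound 1 and compound 3, lie within the usual scatter of each other. Compound 4 `O=C(CCCCC(S)CCS)Nc1ccc([N+](=O)[O-])c(C(F)(F)F)c1` differs from compound 2 by one change: a group of 5 heavy atoms (3 carbon, 2 sulfur; no ring) in place of a group of 5 heavy atoms (3 carbon, 2 sulfur; one five-membered non-aromatic ring with 2 hetero atoms), on a saturated chain carbon, four bonds along the chain from a carbonyl carbon. The entering group is 1,3-disulfanylpropyl. For the measured compounds named here, no measured pair shows this change, so the expectation in this assay is a step no larger than the scatter, in either direction. Compound 4 is estimated at 5%, with an expected range of 0% to 20%.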

Compound 4, percent growth inhibition at one concentration: 1.95%
For compound 4 the middle estimate is 3.1 percentage points above the measured one, within the range that was stated.
By their numbers in this assay, from the lowest: compounds 3, 4 and 1 (each within the scatter of the next).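

Compound 2 has no number in this assay and the step to compound 4 cannot be read. The compounds shown leave open what replacing the five-membered ring with 1,3-disulfanylpropyl does to growth inhibition, and no evidence bears on this result.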